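This account rests on a few compounds, and the source may have more. Where it says the series, first, only, none or still open, it means among the compounds named here.

Three measured compounds share one core and differ only in the group on the carbonyl carbon. In an assay on RBL cells for inhibition of Polyunsaturated fatty acid 5-lipoxygenase (Rattus norvegicus) (on this read-out lower numbers stand for stronger inhibition and higher numbers for weaker inhibition), compound 3 `CCOC(=O)CCC(=O)N(O)C(C)c1ccc2oc(-c3ccccc3)cc2c1` gives 50 nM, the lowest of the three numbers. Compound 1 `COc1ccc(C(=O)N(O)C(C)c2ccc3oc(-c4ccccc4)cc3c2)cc1OC` gives 200 nM, and compound 2 `COc1cccc(OC)c1C(=O)N(O)C(C)c1ccc2oc(-c3ccccc3)cc2c1` gives 3000 nM. The steps of a 4.0-fold lower number from compound 1 to compound 3 (0.60 log units; beyond the scatter) and a 60-fold lower number from compound 2 to compound 3 (1.78 log units; beyond the scatter), together with a 15-fold higher number from compound 1 to compound 2 (1.18 log units; beyond the scatter), show that this position shifts the read-out considerably. Compound 4 `CC(c1ccc2oc(-c3ccccc3)cc2c1)N(O)C(N)=O` carries the change (amino in place of 2-(ethoxycarbonyl)ethyl on a carbonyl carbon), so the carbonyl carbon now bears only amino and the amide-type nitrogen. Every earlier step at this carbon went beyond the scatter, so a step beyond the scatter is expected here too, in a direction the data do not settle. Compound 4 is estimated at 120 nM, with a range from 20 nM to 700 nM, which means an expected step of a 2.4-fold higher number from compound 3 to compound 4 (0.38 log units; beyond the scatter).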

Compound 4, half-maximal inhibitory concentration: 410 nM
For compound 4 the middle estimate is 3.4-fold (0.53 log units) below the measured one; measured number inside the range.
By their numbers in this assay, from the lowest: compound 3; then compound 1; then compound 4; then compound 2.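

In this assay amino on the carbonyl carbon places compound 4 inside the span set by the three larger groups, so this range does not depend on a carbon-linked group here. The number rises when amino replaces 2-(ethoxycarbonyl)ethyl (an 8.2-fold higher number from compound 3 to compound 4 (0.91 log units; beyond the scatter)) or 3,4-dimethoxyphenyl (a 2.1-fold higher number from compound 1 to compound 4 (0.31 log units; beyond the scatter)), but falls when it replaces 2,6-dimethoxyphenyl (a 7.3-fold lower number from compound 2 to compound 4 (0.86 log units; beyond the scatter)). Nothing measured here accounts for this order. The compounds shown leave open how a methylamino group would compare with amino. They also leave open how a carboxylic acid at the end of the chain would compare with the ethyl ester.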